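Flipping a single stereocentre in a weak-acting urea

A few compounds are considered here, and "the series" means these few. Any claim that something is new, unique, unknown or untested is made for them only; others in the source may bear on it.

Measured compounds:
compound 1, `C[C@H](NC(=O)Nc1ccccc1F)c1ccccc1`: 65%
compound 2, `C[C@@H](NC(=O)Nc1c(F)cccc1F)c1ccccc1`: 98%

In an ADME assay on the whole organism with Oryza sativa as the target, tested at 10 uM (on this read-out lower numbers stand for a stronger effect and higher numbers for a weaker effect at the one concentration tested), compound 2 gives 98%, the higher of the two numbers and so the weaker effect of the pair. Its nearest neighbour is compound 1, which in this assay gives 65%, a number well below that of compound 2 and beyond the usual scatter. Compound 3, `C[C@H](NC(=O)Nc1c(F)cccc1F)c1ccccc1`, has not yet been measured. Compared with compound 2 it shows (the two compounds have the same atoms and bonds and differ only in configuration as drawn: 1 of 1 stereo elements differ; a stereocentre at a saturated chain carbon is drawn R in compound 2 and S in compound 3). Among the measured compounds shown here, no pair of measured compounds differs only in this way, so how much a change of configuration alone moves the read-out is unknown here. A single stereocentre can matter, and compound 2 already sits near the top of the scale, so any real shift would likely be downward. The step from compound 2 to compound 3 is expected to be a number 13 percentage points lower from compound 2 to compound 3 (beyond the scatter). Compound 3 is therefore estimated at 85%, within 55% to 100%.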

Compound 3, a percentage reported as activity, at one concentration (the size of the read-out at that concentration, not a potency): 99%
Beside the measured number, compound 3's estimate is 14 percentage points below it; low and high end bracket the measured number.
By their numbers in this assay, from the lowest: compound 1; then compounds 2 and 3 (each within the scatter of the next).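

In this assay, the stereocentre on its own has no readable effect in this difluoro series, and the step is a number 1 percentage points higher from compound 2 to compound 3 (within the scatter). This comparison can be read directly because nothing else changes: the fact that compounds 2 and 3 differ only in the configuration as drawn. The fluoro in place of hydrogen on an aromatic carbon, by contrast, now has a clean single-place comparison, with a step of a number 34 percentage points higher from compound 1 to compound 3 (beyond the scatter), and since higher numbers mean a weaker effect here, the added fluoro goes with a clearly weaker effect at the one concentration tested.

Going by these compounds, whether a chloro or a methoxy group on that same aromatic carbon would give a similar step remains open. The compounds shown also leave open whether configuration matters on the core of compound 1, which has a single fluoro and sits lower on the scale.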